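Pyrazolyl to phenylpyridinyl: a partial reversal expected

The source may hold more compounds than are shown below. What is called first, only, known or untested is meant among the compounds shown, and "the series" means these compounds.

Among the compounds with values here, in a functional assay on MCF7 cells (Homo sapiens) for inhibition, with a stated time of 72 h (on this read-out lower numbers stand for stronger inhibition and higher numbers for weaker inhibition), compound 1 `NC1CCC(Nc2nc(NCc3ccc(-c4ccccc4)cc3)c3ncn(C4CCCC4)c3n2)CC1` gives 583 nM and compound 2 `NC1CCC(Nc2nc(NCc3ccc(-n4cccn4)cc3)c3ncn(C4CCCC4)c3n2)CC1` gives 139 nM, the lower of the two numbers so far. The next structure is compound 3 `NC1CCC(Nc2nc(NCc3ccc(-c4ccccc4)nc3)c3ncn(C4CCCC4)c3n2)CC1`, with this difference: 6-phenylpyridin-3-yl in place of 4-(1H-pyrazol-1-yl)phenyl on a saturated chain carbon bound to a nitrogen on an aromatic ring. In words, 6-phenylpyridin-3-yl stands in place of 4-(1H-pyrazol-1-yl)phenyl on a saturated chain carbon bound to a nitrogen on an aromatic ring.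

Within the data shown here, only one measured step bears on this change: a 4.2-fold lower number from compound 1 to compound 2 (0.62 log units; beyond the scatter), a modest step with 1H-pyrazol-1-yl in place of phenyl on an aromatic carbon. Compound 3 carries a phenyl group again, so part of that step is expected to reverse. Among the measured compounds shown here, no measured compound yet shows what the pyridine ring contributes. The expected change in this assay is therefore upward: a 2.2-fold higher number from compound 2 to compound 3 (0.33 log units; beyond the scatter). Compound 3 is estimated at 300 nM, with an expected range of 110 nM to 800 nM.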

Compound 3, half-maximal inhibitory concentration: 483 nM
For compound 3 the middle estimate is 1.6-fold (0.21 log units) below the measured one; the range from low to high includes it.
By their numbers in this assay, from the lowest: compound 2; then compounds 3 and 1 (each within the scatter of the next).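

In this assay the exchange of 4-(1H-pyrazol-1-yl)phenyl for 6-phenylpyridin-3-yl gives a 3.5-fold higher number from compound 2 to compound 3 (0.54 log units; beyond the scatter), so compound 2 remains the only one of the three set apart by its number. The exchange of 4-phenylphenyl for 6-phenylpyridin-3-yl gives a 1.2-fold lower number from compound 1 to compound 3 (0.08 log units; within the scatter), which means that these two groups cannot be told apart at this position on this read-out. No measurement at hand accounts for either step.

Still open, as far as these compounds go, is whether 6-(1H-pyrazol-1-yl)pyridin-3-yl would keep the lower number of compound 2 or follow compound 3. From the compounds shown here alone, it is also open whether the pyrazole ring itself matters, which a 4-(1H-imidazol-1-yl)phenyl or 4-(morpholin-4-yl)phenyl group at the same place could test.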